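A few compounds are considered here, and "the series" means these few. Any claim that something is new, unique, unknown or untested is made for them only; others in the source may bear on it.

Notes on the series.

Of the compounds shown here, three of the shared core have been measured so far. Compound 1 `CC(C(=O)NCc1ccc(C(F)(F)F)nc1N(C)c1ccccc1)c1ccc(NS(C)(=O)=O)c(F)c1` in a functional assay on CHO-K1 cells for antagonist activity at transient receptor potential cation channel subfamily V member 1 (Homo sapiens), read by FLIPR (on this read-out lower numbers stand for stronger inhibition and higher numbers for weaker inhibition), gives 0.9 nM. Compound 2 `C[C@H](C(=O)NCc1ccc(C(F)(F)F)nc1N1CC[C@@H](OCc2ccccc2)C1)c1ccc(NS(C)(=O)=O)c(F)c1` gives 1.4 nM in this assay, and compound 3 `C[C@H](C(=O)NCc1ccc(C(F)(F)F)nc1N1CC[C@@H](N(C)C)C1)c1ccc(NS(C)(=O)=O)c(F)c1` gives 101 nM. Among the compounds with values here, compound 3 therefore stands with the highest number of the three; its nearest neighbour is compound 2, and the gap between them is the one measured step in this set, a 72-fold higher number from compound 2 to compound 3 (1.86 log units; beyond the scatter). Against compound 1 the gap is wider still, and both gaps lie beyond the scatter.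

Compound 4 `C[C@H](C(=O)NCc1ccc(C(F)(F)F)nc1N1CCC(c2ccccc2)CC1)c1ccc(NS(C)(=O)=O)c(F)c1` is the next member, not yet measured. Compared with compound 3 the change is 4-phenylpiperidin-1-yl in place of 3-(dimethylamino)pyrrolidin-1-yl on an aromatic carbon. The group that enters brings back a carbon-only aromatic ring on the saturated ring, as compound 1 and compound 2 carry one, and removes the dimethylamino that marks compound 3.

Within the data shown here, the one step that bears on this change is a 72-fold higher number from compound 2 to compound 3 (1.86 log units; beyond the scatter). It is large, and the present change undoes the dimethylamino that step introduced, so a step of similar size in the opposite direction is expected for compound 4, a 34-fold lower number from compound 3 to compound 4 (1.53 log units; beyond the scatter), bringing it back toward compound 1 and compound 2. The estimate for compound 4 in this assay is 3 nM, with a range from 0.8 nM to 15 nM.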

Compound 4, inhibition constant: 0.3 nM
Estimate against measurement, compound 4: 10-fold (1.00 log units) above, and the stated range ends above it.
By their numbers in this assay, from the lowest: compound 4; then compounds 1 and 2 (each within the scatter of the next); then compound 3.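

On the aromatic carbon next to the ring nitrogen, 4-phenylpiperidin-1-yl gives a 340-fold lower number from compound 3 to compound 4 (2.53 log units; beyond the scatter) in this assay. This shows that the position accepts a six-membered non-aromatic ring as well as a five-membered one, and that the carbon-only aromatic ring can stand directly on the saturated ring, without the benzyloxy link: compound 2 reads 1.4 nM and compound 4 reads 0.3 nM. The step swaps ring size, substituent and the defined stereocentre all at once, so it cannot be divided among them, and no measurement here accounts for its size.

The compounds shown leave open which of these differences carries the step: 3-phenylpyrrolidin-1-yl and 4-(dimethylamino)piperidin-1-yl would each separate ring size from the substituent. Also open, on these data alone, is how far the phenyl of 4-phenylpiperidin-1-yl can be replaced or extended, for instance by a pyridine ring, a benzyl group or a phenyl carrying a carboxylic acid, and whether an amine placed elsewhere on the piperidine ring would carry the same penalty as the dimethylamino of compound 3.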